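The compounds below may be only part of what the source reports. "The series", "measured", "known", "first", "only" and "open" are said of these compounds alone.

Two compounds share one core and differ only in the group attached to the carbonyl carbon. Compound 1 `COc1ccc(-c2cc3ccccc3nc2/C=C/C(=O)c2c(OC)cccc2OC)cc1` carries 2,6-dimethoxyphenyl there; in a functional assay on NCI-H1299 cells (Homo sapiens) for antiproliferative activity, read by XTT assay, with a stated time of 72 h (a higher number here means a weaker inhibitor, a lower number a stronger inhibitor), compound 1 gives 4710 nM. Compound 2 `COc1ccc(-c2cc3ccccc3nc2/C=C/C(=O)c2cccs2)cc1` carries thiophen-2-yl instead, and in this assay compound 2 gives 720 nM. Among the measured compounds shown here, the single measured step reads a 6.5-fold lower number from compound 1 to compound 2 (0.82 log units; beyond the scatter). For the measured compounds named here, compound 2 therefore holds the lower of the two numbers, with compound 1 as its only neighbour.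

Compound 3 `COc1ccc(-c2cc3ccccc3nc2/C=C/C(=O)c2ccc(Br)s2)cc1` differs from compound 2 by bromo in place of hydrogen on an aromatic carbon. Going by the values given here, no measured step covers a change of this kind; the one step available exchanged the whole ring on the carbonyl carbon and says little about adding a single bromine to that ring. The expected change in this assay is therefore within the scatter: a 1.1-fold lower number from compound 2 to compound 3 (0.04 log units; within the scatter). Compound 3 is expected to give about 650 nM, with a range from 250 nM to 1700 nM.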

Compound 3, half-maximal inhibitory concentration: 710 nM
For compound 3 the middle estimate is 1.1-fold (0.04 log units) below the measured one, within the range that was stated.
By their numbers in this assay, from the lowest: compounds 3 and 2 (each within the scatter of the next); then compound 1.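

In this assay, bromo in place of hydrogen on the ring carbon next to the ring sulfur makes no difference beyond the scatter (a 1.0-fold lower number from compound 2 to compound 3 (0.01 log units; within the scatter)), so this carbon of the thiophen-2-yl group can carry a bromine without a loss, something that the earlier exchange of a whole ring could not show. The advantage over the 2,6-dimethoxyphenyl group also remains with the bromine in place (a 6.6-fold lower number from compound 1 to compound 3 (0.82 log units; beyond the scatter)), so it is seen with both the thiophen-2-yl and the 5-bromothiophen-2-yl group. Nothing available explains why the added bromine leaves the number where it is.

One bromine cannot show whether this carbon accepts any group at all. An amine, a carboxylic acid or a longer chain in the same place might behave quite differently.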